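Chain Extension at the Enone: Compound 4 Anticipated

The source may hold more compounds than are shown below. What is called first, only, known or untested is meant among the compounds shown, and "the series" means these compounds.

In an ADME assay on THP-1 cells (Homo sapiens) for cytotoxicity, read by MTT assay, with a stated time of 72 h (a lower number here means a stronger inhibitor, a higher number a weaker inhibitor), compound 1 `COc1ccc(/C=C/C(=O)c2c(O)c3ccccc3n(Cc3ccccc3)c2=O)cc1OC` gives 28700 nM.
In this assay compound 2 `COc1cc(/C=C/C(=O)c2c(O)c3ccccc3[nH]c2=O)ccc1O` gives 23300 nM.
In this assay compound 3 `COc1cccc(/C=C/C(=O)c2c(O)c3ccccc3[nH]c2=O)c1` gives 38500 nM.

Compound 3 has the highest of the three numbers, yet its distances to compound 1 and compound 2 both lie within the scatter, so no order among them can be claimed. Among the measured compounds shown here, the only single-point step recorded, a 1.7-fold higher number from compound 2 to compound 3 (0.22 log units; within the scatter), also stayed within the scatter. Compound 4 `O=C(/C=C/C=C/c1ccccc1)c1c(O)c2ccccc2[nH]c1=O` differs from compound 3 by 2-phenylethenyl in place of 3-methoxyphenyl on a double-bonded chain carbon bound to a double-bonded chain carbon. For the measured compounds named here, no measured step touches this kind of exchange, so the expectation rests on the flat picture so far: the number for compound 4 is estimated at 35000 nM, with a range from 15000 nM to 80000 nM, meaning an expected step of a 1.1-fold lower number from compound 3 to compound 4 (0.04 log units; within the scatter), not beyond the scatter.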

Compound 4, half-maximal inhibitory concentration: > 50000 nM
Compound 4: a limit, no number; the forecaster's own chance of this, stated with the estimate: 15%; at least 1.4-fold (0.15 log units) between middle value and limit.
By their numbers in this assay, from the lowest: compounds 2, 1 and 3 (each within the scatter of the next). At a limit, above all of these: compound 4.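

Putting 2-phenylethenyl in place of 3-methoxyphenyl on a double-bonded chain carbon bound to a double-bonded chain carbon gives an at least 1.2-fold higher number from compound 3 to compound 4 (0.11 log units; that floor lies within the scatter). Among the compounds shown here, compound 4 is the first compound here to yield a limit rather than a number in this assay: the limit of > 50000 nM in this assay, at which 1 of the 4 values shown sits. This exchange at this place therefore takes the read-out out of the measurable range, although the true size of the step stays unknown. Going by these compounds, whether compound 4 truly lies beyond the scatter from compound 3 remains open. So does what an amine or a carboxylic acid in place of 2-phenylethenyl would give at this place.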